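One More Methyl on the Chain of Compound 2

The source may hold more compounds than are shown below. What is called first, only, known or untested is meant among the compounds shown, and "the series" means these compounds.

In a functional assay on the whole organism for agonist activity, with Mus musculus as the target (on this read-out higher numbers stand for an effect only at larger amounts of compound and lower numbers for an effect already at smaller amounts), compound 1 `O=C1NCCN1CC#CCn1ccnc1` gives 17.3 mg/kg and compound 2 `CN1CCN(CC#CCn2ccnc2)C1=O` gives 1.4 mg/kg, the lower of the two numbers. Compound 3 `CC(C#CCn1ccnc1)N1CCN(C)C1=O` differs from compound 2 by a single change: methyl in place of hydrogen on a saturated chain carbon bound to an amide-type nitrogen in a ring and a triple-bonded carbon. Going by the values given here, the only measured step, a 12-fold lower number from compound 1 to compound 2 (1.09 log units; beyond the scatter), also brings in a methyl, but at another place, so it shows that one methyl can matter greatly without settling the direction here. A modest move to a higher number is expected, a 2.9-fold higher number from compound 2 to compound 3 (0.46 log units; beyond the scatter). For compound 3 the estimated value is 4 mg/kg, with a range of 0.8 mg/kg to 25 mg/kg.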

Compound 3, dose for half-maximal effect: > 100 mg/kg
Compound 3 was reported as a limit (the forecaster's own chance of this, stated with the estimate: 15%); at least 25-fold (1.39 log units) between middle value and limit.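

Methyl in place of hydrogen on a saturated chain carbon bound to an amide-type nitrogen in a ring and a triple-bonded carbon gives an at least 71-fold higher number from compound 2 to compound 3 (1.85 log units; beyond the scatter) in this assay. The earlier methyl, at another place, moved the number the opposite way, so in these compounds the outcome of adding a methyl depends on where it goes. The result for compound 3 is a limit, not a number: the limit of > 100 mg/kg in this assay, at which 1 of the 3 values shown sits.

Still open, on these data alone, is whether an ethyl group or a fluorine atom on this same carbon would act as the methyl does.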